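This account rests on a few compounds, and the source may have more. Where it says the series, first, only, none or still open, it means among the compounds named here.

Three sulfonamides that share one core have been tested in a functional assay on HT-29 cells (Homo sapiens) for antiproliferative activity, read by sulforhodamine B assay, with a stated time of 48 h (a lower number here means a stronger inhibitor, a higher number a weaker inhibitor), and they differ only in the group on a sulfonamide nitrogen. Compound 1 `CCc1ccccc1NS(=O)(=O)c1ccc(N2CCNC2=O)cc1`, an ethylphenyl compound, gives 240 nM. Compound 2 `CCc1cccc(NS(=O)(=O)c2ccc(N3CCNC3=O)cc2)c1`, also an ethylphenyl compound, gives 110 nM. Compound 3 `O=C1NCCN1c1ccc(S(=O)(=O)Nc2ccc(Br)cc2)cc1`, which carries 4-bromophenyl, gives 300 nM.

Where compound 3 stands depends on the comparison: there is a 1.3-fold higher number from compound 1 to compound 3 (0.10 log units; within the scatter), and there is a 2.7-fold higher number from compound 2 to compound 3 (0.44 log units; beyond the scatter). The two ethylphenyl compounds are also separated, with a 2.2-fold lower number from compound 1 to compound 2 (0.34 log units; beyond the scatter).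

For the measured compounds named here, the next compound, compound 4 `Cc1ccc(NS(=O)(=O)c2ccc(N3CCNC3=O)cc2)c(C)c1`, keeps the core and changes only this group, with 2,4-dimethylphenyl in place of 4-bromophenyl on a sulfonamide nitrogen. Going by the values given here, no tested compound carries 2,4-dimethylphenyl, so the evidence is indirect. All three measured steps change this same group and all are modest at most, so no large move is expected in this assay.

Compound 1 at 240 nM and compound 2 at 110 nM carry the groups closest in name to the new one, so a small shift toward a lower number seems likely, probably staying within the scatter. The expected step is a 1.7-fold lower number from compound 3 to compound 4 (0.22 log units; within the scatter). Compound 4 is estimated at 180 nM, with an expected range of 70 nM to 450 nM.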

Compound 4, half-maximal inhibitory concentration: 180 nM
Beside the measured number, compound 4's estimate shows no gap at the digits printed, and the stated range covers the measured number.
By their numbers in this assay, from the lowest: compounds 2, 4, 1 and 3 (each within the scatter of the next, the first and the last beyond it).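

In this assay, putting 2,4-dimethylphenyl in place of 4-bromophenyl on the sulfonamide nitrogen gives a 1.7-fold lower number from compound 3 to compound 4 (0.22 log units; within the scatter) and the comparisons with the two ethylphenyl compounds give a 1.6-fold higher number from compound 2 to compound 4 (0.21 log units; within the scatter) and a 1.3-fold lower number from compound 1 to compound 4 (0.12 log units; within the scatter) so every step to the new group stays within the scatter. This position therefore tolerates a phenyl ring with a new substitution pattern and only carbon in its substituents, and compound 4 cannot be told apart from compound 2 or compound 3 even though those two are separated by a 2.7-fold higher number from compound 2 to compound 3 (0.44 log units; beyond the scatter) and so mark a real, if modest, spread among these groups. No measurement available here explains why these groups give such similar numbers.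

Every group shown is a phenyl ring carrying only small alkyl groups or bromine, so it remains open whether a carboxylic acid, an amine or a longer chain such as hexyl on that ring would move the number beyond the scatter. Also open, as far as these compounds go, is whether a saturated ring such as cyclohexyl, in place of the phenyl ring, would keep the activity seen with these compounds.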